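The source may hold more compounds than are shown below. What is called first, only, known or untested is meant among the compounds shown, and "the series" means these compounds.

Compound 1 `NCC(O)Cn1c(=O)n(C2OC(CO)[C@@H](O)[C@H]2O)c2nc(N)nc(O)c21` holds the higher of the two measured numbers in a functional assay on the whole organism (B cells) with Mus musculus as the target (on this read-out lower numbers stand for smaller maximal responses and higher numbers for larger maximal responses), where compound 1 gives 110%. Compound 2 `C=CCn1c(=S)n(C2OC(CO)[C@@H](O)C(O)[C@H]2O)c2nc(N)nc(O)c21` gives 5% in this assay, a far smaller response, though it differs from compound 1 in more than one place, so its value serves only as a reference point. Compound 3 `N#Cc1cccc(Cn2c(=O)n(C3OC(CO)[C@@H](O)[C@H]3O)c3nc(N)nc(O)c32)c1` has not been measured; it differs from compound 1 by 3-cyanophenyl in place of 2-amino-1-hydroxyethyl on a saturated chain carbon bound to an aromatic nitrogen. For the measured compounds named here, no single-change step of this kind is known, so a moderate downward step is expected, estimated as a number 35 percentage points lower from compound 1 to compound 3 (beyond the scatter). Compound 3 is therefore estimated at 75%, between 25% and 120%.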

Compound 3, largest response reached (reported as maximal response), in percent of the reference or control that the assay uses: 16%
Compound 3: middle estimate off by 59 percentage points, on the high side, outside the stated range (below it).
By their numbers in this assay, from the lowest: compound 2; then compound 3; then compound 1.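

In this assay, the group on a saturated chain carbon bound to an aromatic nitrogen proves decisive: 3-cyanophenyl in place of 2-amino-1-hydroxyethyl gives a number 94 percentage points lower from compound 1 to compound 3 (beyond the scatter). This single change, with the core of compound 1 kept, is enough to lose most of the maximal response. No available evidence speaks to why the response falls.

As far as these compounds go, whether the nitrile, the aromatic ring or the loss of the amine and hydroxyl governs this drop remains open. A plain benzyl group or a 3-hydroxypropyl chain at this place would help to separate these.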